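Swapping piperidine for pyrrolidine: plasma free fraction outlook

A few compounds are considered here, and "the series" means these few. Any claim that something is new, unique, unknown or untested is made for them only; others in the source may bear on it.

The study concerns a set of amides built on a shared core, with the unbound fraction read in an ADME assay on a cell-free system (plasma, Rattus norvegicus); on this read-out lower numbers stand for a smaller free fraction and higher numbers for a larger free fraction. Compound 1 `CC(=O)Nc1cc(-c2ccc(N(C)C(=O)c3c(C)cccc3F)c(N3CC4CC4C3)c2)n(C(C)C)n1` gives 0.002 in this assay. Compound 2 `CC(=O)Nc1cc(-c2ccc(N(C)C(=O)c3c(F)cccc3Cl)c(N3CCCCC3)c2)n(C(C)C)n1` gives 0.001, which is the lowest of the two numbers reported, though its gap to compound 1 is within the scatter, so the two cannot be ordered. Compound 3 `CC(=O)Nc1cc(-c2ccc(N(C)C(=O)c3c(F)cccc3Cl)c(N3CC4CC4C3)c2)n(C2CCCC2)n1` returns only a limit of the assay, < 0.0005, not a number; this is the limit of < 0.0005 in this assay, at which 1 of the 3 values shown sits.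

Compound 4 `CC(=O)Nc1cc(-c2ccc(N(C)C(=O)c3c(F)cccc3Cl)c(N3CCCC3)c2)n(C(C)C)n1` has not yet been measured in this assay. It differs from compound 2 in one place: pyrrolidin-1-yl in place of piperidin-1-yl on an aromatic carbon. Within the data shown here, no step between two measured compounds maps this change, so the direction has to be judged from the general level of the series, where every reported number sits very low. The change is expected to move the unbound fraction little, if at all, in this assay, and not beyond the scatter in either direction. Compound 4 is therefore estimated at 0.0015, within a range of 0.0005 to 0.004, which would mean a step of a 1.5-fold higher number from compound 2 to compound 4 (0.18 log units; within the scatter).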

Compound 4, unbound fraction: 0.009
Compound 4: the middle estimate sits 6.0-fold (0.78 log units) below what was measured; the whole stated range lies below it.
By their numbers in this assay, from the lowest: compounds 2 and 1 (each within the scatter of the next); then compound 4. At a limit, below all of these: compound 3.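

Exchanging piperidin-1-yl for pyrrolidin-1-yl on the aromatic carbon ortho to the ((2-chloro-6-fluorophenyl)carbonyl)(methyl)amino group gives, in this assay, a 9.0-fold higher number from compound 2 to compound 4 (0.95 log units; beyond the scatter). Compounds 1, 2 and 3 differ from one another in more than one place, so they could not show that this assay responds to this ring alone; this pair shows it, with everything else in the two structures held the same. Among these compounds, compound 3 still returns a limit of the assay and not a number, so it adds no measured step to this picture: the limit of < 0.0005 in this assay, at which 1 of the 4 values shown sits.

The compounds shown leave open how a morpholine ring, an azetidine ring or an open-chain dimethylamino group on this same carbon would read, and so whether the free fraction follows ring size at all or is particular to this one exchange. They also leave open whether pyrrolidin-1-yl gives a step of similar size alongside a cyclopentyl group in place of the isopropyl group, or with a different benzoyl group on the amide, and this single pair gives no reason for the step.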